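The source may hold more compounds than are shown below. What is called first, only, known or untested is meant among the compounds shown, and "the series" means these compounds.

Compound 1 `O=C1NCCN1c1ccc(S(=O)(=O)Nc2ccc3[nH]ccc3c2)cc1`: 130 nM
Compound 2 `O=C1NCCN1c1ccc(S(=O)(=O)Nc2ccc(C3CCCCC3)cc2)cc1`: > 1000 nM
Compound 3 `COc1ccc(NS(=O)(=O)c2ccc(N3CCNC3=O)cc2)cc1OC`: 520 nM

Three compounds share one core and differ only in the aromatic group carried by the sulfonamide nitrogen. All were tested in a functional assay on HT-29 cells (Homo sapiens) for antiproliferative activity, read by sulforhodamine B assay, with a stated time of 48 h; on this read-out higher numbers stand for weaker inhibition and lower numbers for stronger inhibition. Compound 1 gives 130 nM in this assay, and compound 3 gives 520 nM. For compound 2 this assay reports only a limit, > 1000 nM, and not a number. Compound 2 therefore stands at the edge of what this assay can resolve (the limit of > 1000 nM in this assay, at which 1 of the 3 values shown sits), while compounds 1 and 3 both return numbers.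

The new compound 4 `CCCCOc1ccc(NS(=O)(=O)c2ccc(N3CCNC3=O)cc2)cc1` keeps everything of compound 2 except one place: butoxy in place of cyclohexyl on an aromatic carbon. Among the compounds with values here, no step between two measured compounds that differ in a single place is available, so the outcome rests on a loose comparison. Compound 3, whose aromatic group also carries oxygen-linked substituents, gives a number rather than a limit, which is the only hint that an oxygen-linked chain may fare better than a cyclohexyl ring here. The expected step of an at least 1.2-fold lower number from compound 2 to compound 4 (0.09 log units; that floor lies within the scatter) is a modest move toward stronger inhibition, possibly not clearing the scatter. Compound 4 is thus expected to give about 800 nM, somewhere between 250 nM and 2500 nM.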

Compound 4, half-maximal inhibitory concentration: 630 nM
Beside the measured number, compound 4's estimate is 1.3-fold (0.10 log units) above it; the measured number falls inside the stated range.
By their numbers in this assay, from the lowest: compound 1; then compounds 3 and 4 (each within the scatter of the next). At a limit, above all of these: compound 2.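

Compound 2 has only a limit in this assay, not a number: the limit of > 1000 nM in this assay, at which 1 of the 4 values shown sits. Replacing its cyclohexyl with butoxy, on an aromatic carbon para to a large group, gives an at least 1.5-fold lower number from compound 2 to compound 4 (0.20 log units; that floor lies within the scatter). This is the first single-place change shown at this position, and it yields a measured number: compound 4 gives 630 nM, so an open chain joined through oxygen is compatible with measurable activity here. Going by these compounds, the true size of the step stays unknown, as the printed figure is only a floor and that floor does not clear the usual scatter.

The change swaps a carbon ring for an oxygen-linked chain, so this one pair cannot separate the effect of losing the ring from that of adding the oxygen; a pentyl chain, which has no oxygen, or a cyclohexyloxy group, which keeps both ring and oxygen, would pull the two apart. The compounds shown also leave open how a longer chain such as hexyloxy, a shorter one such as ethoxy, or an amine would fare at this same position.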